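A methoxyphenyl swap tested on human liver cells

The source may report more compounds than this note shows. Statements on the series, on what has been measured and on what is new or still open speak of the compounds shown alone.

Compound 1 `COc1ccc(-n2nncc2CN2C(=O)C3(C(C#N)=C(N)Oc4c3c3nc5ccccc5nc3c3ccccc43)c3ccccc32)cc1` carries a 4-methoxyphenyl on an aromatic nitrogen. In an ADME assay on L02 cells (Homo sapiens) for antiproliferative activity, read by MTT assay, with a stated time of 48 h (on this read-out higher numbers stand for weaker inhibition and lower numbers for stronger inhibition), compound 1 reaches only the limit of the assay, > 50000 nM. Compound 2 `COc1ccccc1-n1nncc1CN1C(=O)C2(C(C#N)=C(N)Oc3c2c2nc4ccccc4nc2c2ccccc32)c2ccccc21` is related to it by 2-methoxyphenyl in place of 4-methoxyphenyl on an aromatic nitrogen. In this assay compound 2 likewise stops at the limit, > 50000 nM. The step that the two limits leave unreadable from compound 1 to compound 2 therefore cannot be read, as both values sit at the limit of > 50000 nM in this assay, at which 3 of the 3 values shown sit. Compound 3 `COc1ccc(-n2nncc2CN2C(=O)C3(C(C#N)=C(N)Oc4c(N)cc5nc6ccccc6nc5c43)c3ccccc32)cc1` rests on a different core; the difference between the two cores is not broken down here. In this assay compound 3 also gives only the limit, > 50000 nM. Compound 4 `COc1ccccc1-n1nncc1CN1C(=O)C2(C(C#N)=C(N)Oc3c(N)cc4nc5ccccc5nc4c32)c2ccccc21` has not yet been measured; it differs from compound 3 by 2-methoxyphenyl in place of 4-methoxyphenyl on an aromatic nitrogen, the same change that links compound 1 to compound 2, at the same place. Because compound 1 and compound 2 both sit at the limit of > 50000 nM in this assay, at which 3 of the 3 values shown sit, the same change is expected to leave compound 4 at the limit as well. The estimate for compound 4 in this assay is 60000 nM, with a range from 30000 nM to 200000 nM. This expectation amounts to a step that the limit leaves unreadable from compound 3 to compound 4, essentially flat.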

Compound 4, half-maximal inhibitory concentration: > 50000 nM
Compound 4: a limit, no number; the forecaster's own chance of this, stated with the estimate: 85%; the middle value does not contradict the limit.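

Compound 4 also gives only a limit in this assay, so no size can be read for the step between compound 3 and compound 4: the limit of > 50000 nM in this assay, at which 4 of the 4 values shown sit.

The compounds shown leave open whether 2-methoxyphenyl and 4-methoxyphenyl differ at all on either core in this assay, and at what concentration any of the four compounds would inhibit these cells.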